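Swapping one 3-nitrophenyl group in compound 1

The source may hold more compounds than are shown below. What is called first, only, known or untested is meant among the compounds shown, and "the series" means these compounds.

Values so far in a functional assay on HepG2 cells (Homo sapiens) for cytotoxicity, read by MTT assay, with a stated time of 24 h; a lower number here means a stronger inhibitor, a higher number a weaker inhibitor
Compound 1 `O=C1/C(=C/c2cccc([N+](=O)[O-])c2)CN(S(=O)(=O)c2ccc(F)cc2)C/C1=C\c1cccc([N+](=O)[O-])c1` gives 8760 nM
Compound 2 `CC(=O)Nc1ccc(S(=O)(=O)N2C/C(=C\c3cccc([N+](=O)[O-])c3)C(=O)/C(=C/c3cccc([N+](=O)[O-])c3)C2)cc1` gives 7140 nM
Compound 3 `CC(=O)Nc1ccc(S(=O)(=O)N2C/C(=C\c3ccc(C#N)cc3)C(=O)/C(=C/c3ccc(C#N)cc3)C2)cc1` gives 4880 nM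

Compound 1 stands within the scatter of both compound 2 and compound 3, so the three values set no order among these compounds. The next compound, compound 4 `COc1cc(/C=C2\CN(S(=O)(=O)c3ccc(F)cc3)C/C(=C\c3cccc([N+](=O)[O-])c3)C2=O)cc(OC)c1OC`, departs from compound 1 in one place: 3,4,5-trimethoxyphenyl in place of 3-nitrophenyl on a double-bonded chain carbon bound to a double-bonded ring carbon. That is, 3,4,5-trimethoxyphenyl takes the place of 3-nitrophenyl on a double-bonded chain carbon bound to a double-bonded ring carbon.

Among the measured compounds shown here, no measured step covers this exchange. The only one available is a 1.2-fold lower number from compound 1 to compound 2 (0.09 log units; within the scatter), which replaces fluoro with acetamido on an aromatic carbon, a different change that stays within the scatter. It bears on compound 4 only indirectly, as a sign of how little these values have moved so far. On that basis, no step beyond the scatter is expected in this assay. The expected result is a 1.5-fold lower number from compound 1 to compound 4 (0.16 log units; within the scatter). For compound 4 the estimate is 6000 nM, with an expected range from 2500 nM to 15000 nM.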

Compound 4, half-maximal inhibitory concentration: 3250 nM
Compound 4: the middle estimate sits 1.8-fold (0.27 log units) above what was measured, within the range that was stated.
By their numbers in this assay, from the lowest: compounds 4, 3, 2 and 1 (each within the scatter of the next, the first and the last beyond it).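

In this assay, putting 3,4,5-trimethoxyphenyl in place of one 3-nitrophenyl on a double-bonded chain carbon bound to a double-bonded ring carbon gives a 2.7-fold lower number from compound 1 to compound 4 (0.43 log units; beyond the scatter), the first single change shown to go beyond the scatter. The other single change, a 1.2-fold lower number from compound 1 to compound 2 (0.09 log units; within the scatter), sits on an aromatic carbon and stays within the scatter, so of the two places changed from compound 1, only this one has shifted the number, and only modestly. Nothing among the data shown accounts for the step.

The compounds shown leave open whether the remaining 3-nitrophenyl can be exchanged in the same way with a further shift. They also leave open how an amine or a carboxylic acid on the phenyl ring at this place would compare.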